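Isopropyl Removed from Compound 2: Expecting Compound 4

The compounds below may be only part of what the source reports. "The series", "measured", "known", "first", "only" and "open" are said of these compounds alone.

Compound 2 `CC(C)C/N=C(\S)NCCCCn1nc(-c2ccccc2)ccc1=O` was tested in a functional assay on the whole organism (stomach) with Rattus norvegicus as the target; on this read-out higher numbers stand for an effect only at larger amounts of compound and lower numbers for an effect already at smaller amounts. In that test compound 2 gives only a limit of the assay, > 100 mg/kg, and no number. Compound 1 `CC/N=C(/NC#N)NCCCCCn1nc(-c2ccccc2)ccc1=O` gives 100 mg/kg in this assay. Compound 3 `C/N=C(/NC#N)NCCCCCn1nc(-c2ccccc2)cc(C)c1=O` likewise reaches only a limit, > 100 mg/kg. What the three values share is the limit of > 100 mg/kg in this assay, at which 2 of the 3 values shown sit. Compound 4 `C/N=C(\S)NCCCCn1nc(-c2ccccc2)ccc1=O` differs from compound 2 by hydrogen in place of isopropyl on a saturated chain carbon bound to a double-bonded nitrogen. For the measured compounds named here, no step between measured compounds is known, and compound 2 itself shows only a limit, so the direction of this change has nothing to lean on. The expected step that the limit leaves unreadable from compound 2 to compound 4 is therefore small, none beyond the scatter. Compound 4 is expected to give 150 mg/kg in this assay, within 60 mg/kg to 400 mg/kg.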

Compound 4, dose for half-maximal effect: 28.9 mg/kg
Compound 4: the middle estimate sits 5.2-fold (0.72 log units) above what was measured, and the stated range ends above it.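

Hydrogen in place of isopropyl on a saturated chain carbon bound to a double-bonded nitrogen gives, in this assay, an at least 3.4-fold lower number from compound 2 to compound 4 (0.53 log units; beyond the scatter). For the compounds shown here, this is the first readable step, and it shows that this place can shift the amount of compound needed for an effect. The true size of the step stays unknown because one end of it is only a limit: the limit of > 100 mg/kg in this assay, at which 2 of the 4 values shown sit.

From the compounds shown here alone, whether a propyl chain, a hydroxyl or an amine at this place would do the same stays open. So does whether hydrogen here would help on the other cores.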